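A few compounds are considered here, and "the series" means these few. Any claim that something is new, unique, unknown or untested is made for them only; others in the source may bear on it.

The measured compounds in a functional assay on UACC-62 cells (Homo sapiens) for inhibition, read by sulforhodamine B assay, with a stated time of 48 h; on this read-out lower numbers stand for stronger inhibition of growth and higher numbers for weaker inhibition of growth:
Compound 1 `CC1=CC[C@H](C(C)(C)NC(=S)N/N=C/c2ccccc2)CC1` gives only a limit, > 100000 nM (the limit of > 100000 nM in this assay, at which 1 of the 3 values shown sits).
Compound 2 `CC1=CC[C@H](C(C)(C)NC(=S)N/N=C/c2ccccc2O)CC1` gives 10800 nM.
Compound 3 `CC1=CC[C@H](C(C)(C)NC(=S)N/N=C/c2ccccc2Cl)CC1` gives 98000 nM.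

Of the two numbers, compound 3 stands highest, compound 2 being nearest at a 9.1-fold higher number from compound 2 to compound 3 (0.96 log units; beyond the scatter). Compound 4 `CC1=CC[C@H](C(C)(C)NC(=S)N/N=C/c2ccccc2[N+](=O)[O-])CC1` differs from compound 3 by nitro in place of chloro on an aromatic carbon. Among the measured compounds shown here, two measured steps touch the same aromatic carbon: an at least 1.0-fold lower number from compound 1 to compound 3 (0.00 log units; that floor lies within the scatter), a step within the scatter, and a 9.1-fold higher number from compound 2 to compound 3 (0.96 log units; beyond the scatter), a modest rise. On these data alone, neither involves nitro, so the new group is untested here. Since the change brings acceptors but no donor, compound 4 is expected to stay close to compound 3, an estimated 1.6-fold lower number from compound 3 to compound 4 (0.21 log units; within the scatter). Compound 4 is therefore estimated at 60000 nM, ranging from 15000 nM to 100000 nM.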

Compound 4, concentration for total growth inhibition: 92200 nM
Compound 4: the middle estimate sits 1.5-fold (0.19 log units) below what was measured; measured number inside the range.
By their numbers in this assay, from the lowest: compound 2; then compounds 4 and 3 (each within the scatter of the next). At a limit, above all of these: compound 1.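

In this assay, nitro in place of chloro on this aromatic carbon, ortho to a large group, gives a 1.1-fold lower number from compound 3 to compound 4 (0.03 log units; within the scatter), so the two groups cannot be told apart here. Compound 2, with hydroxy at the same carbon, stays clearly separate from the nitro compound, with an 8.5-fold higher number from compound 2 to compound 4 (0.93 log units; beyond the scatter). Compound 1 gives only a limit: the limit of > 100000 nM in this assay, at which 1 of the 4 values shown sits. The step from that limit is an at least 1.0-fold lower number from compound 1 to compound 4 (0.03 log units; that floor lies within the scatter), which is a floor and cannot be read as a measured difference.

On these data alone, whether an amine or a carboxylic acid on this carbon would fall with hydroxy or with chloro and nitro remains open.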